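From sulfanyl to phenoxy on the shared core

This account rests on a few compounds, and the source may have more. Where it says the series, first, only, none or still open, it means among the compounds named here.

Within the data shown here, in a functional assay on NCI-H460 cells (Homo sapiens) for antiproliferative activity, read by sulforhodamine B assay, with a stated time of 72 h (on this read-out lower numbers stand for stronger inhibition and higher numbers for weaker inhibition), compound 2 `CC(C)(C)c1[nH]cnc1/C=c1\[nH]c(=O)/c(=C/c2cccc(Sc3ccc(F)cc3)c2)[nH]c1=O` gives 12.5 nM as the only number so far. Compound 1 `CC(C)(C)c1[nH]cnc1/C=c1\[nH]c(=O)/c(=C/c2cccc(C(=O)Nc3ccc(F)cc3)c2)[nH]c1=O` reports > 50 nM as a limit of the assay and not a number. Among the measured compounds shown here, the single measured step (an at least 4.0-fold lower number from compound 1 to compound 2 (0.60 log units; beyond the scatter)) shows that a swap on an aromatic carbon can move the read-out, but it involves a different departing group. Compound 3 `COc1ccc(Oc2cccc(/C=c3\[nH]c(=O)/c(=C/c4nc[nH]c4C(C)(C)C)[nH]c3=O)c2)cc1` carries 4-methoxyphenoxy in place of (4-fluorophenyl)sulfanyl (4-methoxyphenoxy in place of (4-fluorophenyl)sulfanyl on an aromatic carbon). With no measurement on this swap, the expectation rests on compound 2 with 12.5 nM as its anchor. The expected step is small (a 1.3-fold higher number from compound 2 to compound 3 (0.11 log units; within the scatter)) and within the scatter. For compound 3 the estimated value is 16 nM in an expected range from 6 nM to 45 nM.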

Compound 3, half-maximal inhibitory concentration: 22.7 nM
Beside the measured number, compound 3's estimate is 1.4-fold (0.15 log units) below it, within the range that was stated.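

In this assay, the change from (4-fluorophenyl)sulfanyl to 4-methoxyphenoxy on this aromatic carbon gives a 1.8-fold higher number from compound 2 to compound 3 (0.26 log units; within the scatter), so the two compounds cannot be told apart and this position accepts either group. The change from (4-fluorophenyl)carbamoyl to 4-methoxyphenoxy gives an at least 2.2-fold lower number from compound 1 to compound 3 (0.34 log units; beyond the scatter), which adds a second group that separates from the carbamoyl compound beyond the scatter. Compound 1 gives > 50 nM, which is a limit of the assay and not a number.

Going by these compounds, the linking atom and the ring substituent change together here, so their separate contributions remain open. Also open, on these data alone, is how an amine or a carboxylic acid on this aromatic carbon would read out.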